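This account rests on a few compounds, and the source may have more. Where it says the series, first, only, none or still open, it means among the compounds named here.

In a functional assay on PC-3 cells (Homo sapiens) for inhibition, read by MTT assay, with a stated time of 48 h (on this read-out higher numbers stand for weaker inhibition and lower numbers for stronger inhibition), the compounds measured so far are:

- compound 1 `CCN1CCN(C(=S)SCCCOc2ccc3c(=O)c(-c4ccc(OC)cc4)coc3c2)CC1`: 7080 nM
- compound 2 `COc1ccc(-c2coc3cc(OCCCSC(=S)N4CCN(Cc5ccccc5)CC4)ccc3c2=O)cc1`: 14900 nM
- compound 3 `COc1ccc(-c2coc3cc(OCCCSC(=S)N4CCN(c5ccccn5)CC4)ccc3c2=O)cc1`: 17400 nM

Compound 1 gives the lowest of these numbers, and its steps to the other two lie beyond the scatter. Compound 4 `COc1ccc(-c2coc3cc(OCCCCBr)ccc3c2=O)cc1` has not yet been measured. It differs from compound 1 as follows: a group of 2 heavy atoms (1 carbon, 1 bromine; no ring) in place of a group of 11 heavy atoms (7 carbon, 2 nitrogen, 2 sulfur; one six-membered non-aromatic ring with 2 hetero atoms), on a saturated chain carbon, three bonds along the chain from an oxygen on an aromatic ring.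

The measured steps bear on this change only indirectly, as each alters just the substituent on the amine nitrogen in the ring. Two of them start from compound 1 and are modest: a 2.1-fold higher number from compound 1 to compound 2 (0.32 log units; beyond the scatter), and a 2.5-fold higher number from compound 1 to compound 3 (0.39 log units; beyond the scatter). The third, a 1.2-fold higher number from compound 2 to compound 3 (0.07 log units; within the scatter), stays within the scatter. Every measured compound keeps the six-membered non-aromatic ring, so the data do not show what removing it does. Both changes made to compound 1 raised the number, so a step in that same direction is expected in this assay, at least as large as those modest ones but poorly defined. The expected change is a 3.5-fold higher number from compound 1 to compound 4 (0.55 log units; beyond the scatter). In this assay, compound 4 is estimated at 25000 nM, with an expected range from 9000 nM to 70000 nM.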

Compound 4, half-maximal inhibitory concentration: 55600 nM
Compound 4: middle estimate off by 2.2-fold (0.35 log units), on the low side, within the range that was stated.
By their numbers in this assay, from the lowest: compound 1; then compounds 2 and 3 (each within the scatter of the next); then compound 4.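

In this assay, the place on a saturated chain carbon, three bonds along the chain from an oxygen on an aromatic ring, now has a reading for a group without the six-membered non-aromatic ring: bromomethyl in place of the whole group of compound 1 gives a 7.9-fold higher number from compound 1 to compound 4 (0.90 log units; beyond the scatter) and so stands furthest from compound 1 of the compounds shown. This change removes the ring, both nitrogen atoms and both sulfur atoms at once, and its step is larger than those seen when only the substituent on the amine nitrogen was altered, a 2.1-fold higher number from compound 1 to compound 2 (0.32 log units; beyond the scatter) and a 2.5-fold higher number from compound 1 to compound 3 (0.39 log units; beyond the scatter), so the whole group matters more to the number than that substituent does. No measurement is at hand that explains this step.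

The compounds shown leave open which part of the removed group accounts for the difference, since the ring, the nitrogen atoms and the sulfur atoms all leave together. A simple amine such as dimethylamino or morpholine at this place, or a carboxylic acid there, would begin to separate those parts.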